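Hydroxy for chloro on the aryl ring of compound 2

This account rests on a few compounds, and the source may have more. Where it says the series, first, only, none or still open, it means among the compounds named here.

Of the compounds shown here, three have numbers so far. Compound 1 `Cn1c(NN)nc(-c2cccc(O)c2O)c(C#N)c1=O` in a functional assay, with a stated time of 20 min (a lower number here means a stronger inhibitor, a higher number a weaker inhibitor), gives 34 ug/mL. Compound 2 `CCOC(=O)c1cnn(-c2nc(-c3ccccc3Cl)c(C#N)c(=O)n2C)c1N` in this assay gives 78 ug/mL. Compound 3 `Cn1c(NN)nc(-c2ccc(Cl)cc2)c(C#N)c1=O` in this assay gives 44 ug/mL. Among these, compound 2 carries the highest number; compound 3 stands nearest, with a gap within the scatter, while compound 1 stands furthest, with a gap beyond the scatter. Among the compounds with values here, no pair among the three differs in only one place, so no single step can be read from them.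

Compound 4 `CCOC(=O)c1cnn(-c2nc(-c3ccccc3O)c(C#N)c(=O)n2C)c1N` is not yet measured. It is built from compound 2 by a single change: hydroxy in place of chloro on an aromatic carbon, the aryl ring going from 2-chlorophenyl to 2-hydroxyphenyl. Within the data shown here, the only guide is the comparison of compound 1, which carries a hydroxy-bearing aryl ring, with compound 3, which carries a chloro-bearing aryl ring, on another core; their two values lie within the scatter of each other and give no direction.

The expected step from compound 2 to compound 4 in this assay is therefore small, a 1.3-fold lower number from compound 2 to compound 4 (0.11 log units; within the scatter), with no change beyond the scatter. Compound 4 in this assay is estimated at 60 ug/mL, in the range 30 ug/mL to 120 ug/mL.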

Compound 4, half-maximal inhibitory concentration: 48 ug/mL
Beside the measured number, compound 4's estimate is 1.3-fold (0.10 log units) above it, within the range that was stated.
By their numbers in this assay, from the lowest: compounds 1, 3, 4 and 2 (each within the scatter of the next, the first and the last beyond it).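

Within the data shown here, on the shared core, the step from 2-chlorophenyl to 2-hydroxyphenyl can now be read directly in this assay as a 1.6-fold lower number from compound 2 to compound 4 (0.21 log units; within the scatter) and this is the first single-place comparison. At this aromatic carbon, ortho to a large group, hydroxy can therefore stand in place of chloro without a change that can be told from the scatter. The hydrogen-bond donor and acceptor that enter with hydroxy leave no effect beyond the scatter in this assay and no measurement on hand offers an explanation for this result.

On these data alone, whether this position stays as undemanding for other groups remains open, since an amine, a methoxy group or a carboxylic acid on the same aromatic carbon would test the reading beyond hydroxy and chloro. As far as these compounds go, it also remains open whether hydroxy in place of chloro gives a step of similar size on another core, such as the core of compound 1, where only a matched pair differing in this one place could answer the question.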